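Benzyl in place of 2-methylphenyl on the ring nitrogen

This account rests on a few compounds, and the source may have more. Where it says the series, first, only, none or still open, it means among the compounds named here.

Measured so far in a functional assay on MGC-803 cells (Homo sapiens) for inhibition, read by MTT assay, with a stated time of 72 h; a higher number here means a weaker inhibitor, a lower number a stronger inhibitor:
Compound 1 `CC(C)n1ncc2c(C(=O)NCc3cn(-c4ccc(F)cc4)nn3)cccc21` gives > 40000 nM, a limit of the assay.
Compound 2 `CC(C)n1ncc2c(C(=O)NCc3cn(-c4cccc(Br)c4)nn3)cccc21` gives > 40000 nM, a limit of the assay.
Compound 3 `Cc1ccccc1-n1cc(CNC(=O)c2cccc3c2cnn3C(C)C)nn1` gives > 40000 nM, a limit of the assay.

Compound 3 thus stands only at a limit, and every value shown sits there (the limit of > 40000 nM in this assay, at which 3 of the 3 values shown sit). The steps a step that the two limits leave unreadable from compound 1 to compound 2, a step that the two limits leave unreadable from compound 1 to compound 3 and a step that the two limits leave unreadable from compound 2 to compound 3 are all unreadable, each running between two limits. Compound 4 `CC(C)n1ncc2c(C(=O)NCc3cn(Cc4ccccc4)nn3)cccc21` differs from compound 3 by benzyl in place of 2-methylphenyl on an aromatic nitrogen. No readable step bears on this change, so no size or direction can be drawn from the measured steps; the expected step is a number no higher from compound 3 to compound 4 (the limit leaves the size open), flat. Compound 4 is expected at 40000 nM, range 15000 nM to 200000 nM, and most probably again only a limit in this assay.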

Compound 4, half-maximal inhibitory concentration: 14300 nM
Compound 4: middle estimate off by 2.8-fold (0.45 log units), on the high side; the measured number lies below the stated range.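

In this assay, going by these compounds alone, benzyl on this aromatic nitrogen gives the first readable change at this position: an at least 2.7-fold lower number from compound 3 to compound 4 (0.44 log units; beyond the scatter), an at least 2.7-fold lower number from compound 2 to compound 4 (0.44 log units; beyond the scatter) and an at least 2.7-fold lower number from compound 1 to compound 4 (0.44 log units; beyond the scatter). All three steps point the same way, from a substituted phenyl group to benzyl, while the steps among compound 1, compound 2 and compound 3 cannot be read. Only compound 4 leaves the limit: the limit of > 40000 nM in this assay, at which 3 of the 4 values shown sit.

On these data alone, the full size of each step stays open, as each starts from a limit. Also open, as far as these compounds go, is what a longer chain such as phenethyl, or an amine on the benzyl ring, would do here.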